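Nitro in Place of Hydrogen on Compound 3

A few compounds are considered here, and "the series" means these few. Any claim that something is new, unique, unknown or untested is made for them only; others in the source may bear on it.

Compound 3 `O=C(CSC(=S)N[C@H]1CCOC1=O)Nc1ccc(C(=O)/C=C/c2ccccc2)cc1` gives 24800 nM in a functional assay on MGC-803 cells (Homo sapiens) for cytotoxicity, read by MTT assay, with a stated time of 72 h (on this read-out lower numbers stand for stronger inhibition and higher numbers for weaker inhibition), the highest of the three numbers measured. Compound 1 `CCOC(=O)c1ccc(NC(=O)CSC(=S)N[C@H]2CCOC2=O)cc1` gives 21700 nM and compound 2 `O=C(CSC(=S)N[C@H]1CCOC1=O)Nc1ccc(C(=O)/C=C/c2ccc(Cl)cc2)cc1` gives 6900 nM. The step of a 1.1-fold higher number from compound 1 to compound 3 (0.06 log units; within the scatter) lies within the scatter, whereas a 3.6-fold higher number from compound 2 to compound 3 (0.56 log units; beyond the scatter) lies beyond it. Compound 4 `O=C(CSC(=S)N[C@H]1CCOC1=O)Nc1ccc(C(=O)/C=C/c2ccc([N+](=O)[O-])cc2)cc1` differs from compound 3 by nitro in place of hydrogen on an aromatic carbon. Going by the values given here, the one step that bears on this change is a 3.6-fold higher number from compound 2 to compound 3 (0.56 log units; beyond the scatter), in which hydrogen replaced chloro on the same ring and the number rose; the evidence for nitro itself is indirect. Compound 4 is therefore expected to give a modestly lower number, a 3.1-fold lower number from compound 3 to compound 4 (0.49 log units; beyond the scatter). Compound 4 is estimated at 8000 nM, with a range from 3000 nM to 25000 nM.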

Compound 4, half-maximal inhibitory concentration: 29400 nM
Estimate against measurement, compound 4: 3.7-fold (0.57 log units) below, outside the stated range (above it).
By their numbers in this assay, from the lowest: compound 2; then compounds 1, 3 and 4 (each within the scatter of the next).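

In this assay, nitro on this aromatic carbon does not separate from hydrogen (a 1.2-fold higher number from compound 3 to compound 4 (0.07 log units; within the scatter)), so the lower number seen with chloro does not extend to nitro (a 4.3-fold higher number from compound 2 to compound 4 (0.63 log units; beyond the scatter)). The 2-(4-nitrophenyl)ethenyl group also stays level with ethoxy on the carbonyl carbon (a 1.4-fold higher number from compound 1 to compound 4 (0.13 log units; within the scatter)). Nothing measured here accounts for chloro and nitro parting at this position.

From the compounds shown here alone, whether bromo, methoxy or an amine on this carbon would track chloro or hydrogen remains open. So does whether chloro's step reflects a trend across halogens.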